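The compounds below may be only part of what the source reports. "The series", "measured", "known", "first", "only" and "open" are said of these compounds alone.

Measured in a functional assay on MDA-MB-231 cells (Homo sapiens) for antiproliferative activity, read by XTT assay, with a stated time of 72 h; on this read-out higher numbers stand for weaker inhibition and lower numbers for stronger inhibition:
- Compound 1 `COc1ccc(-c2cc3ccccc3nc2C=O)cc1`: > 10000 nM, which is a limit of the assay and not a number.
- Compound 2 `COc1ccc(-c2cc3ccccc3nc2/C=C/C(=O)c2ccc(OC)cc2OC)cc1`: 3210 nM
- Compound 3 `COc1ccc(-c2cc3ccccc3nc2/C=C/C(=O)c2c(OC)cccc2OC)cc1`: 5630 nM

Compound 3 gives 5630 nM. Going by the values given here, only one other true number stands beside it, and the gap is small: a 1.8-fold higher number from compound 2 to compound 3 (0.24 log units; within the scatter).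

Compound 4 `COc1ccc(-c2cc3ccccc3nc2/C=C/C(=O)c2ccccn2)cc1` has not yet been measured. It differs in one place, with pyridin-2-yl in place of 2,6-dimethoxyphenyl on a carbonyl carbon.

Among the compounds with values here, only one measured step bears on this change. Within the data shown here, it acted on the same carbonyl carbon, but it swapped only one dimethoxyphenyl group for another, whereas here the whole group is replaced. That makes it a weak guide, so the range must stay wide. Compound 3 was reached by a 1.8-fold higher number from compound 2 to compound 3 (0.24 log units; within the scatter), so no step beyond the scatter is expected in this assay. The expected change is a 1.1-fold higher number from compound 3 to compound 4 (0.03 log units; within the scatter). For compound 4 the estimated value is 6000 nM, with an expected range of 2000 nM to 18000 nM.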

Compound 4, half-maximal inhibitory concentration: 740 nM
Compound 4: middle estimate off by 8.1-fold (0.91 log units), on the high side; measured number outside the range, below it.
By their numbers in this assay, from the lowest: compound 4; then compounds 2 and 3 (each within the scatter of the next). At a limit, above all of these: compound 1.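

In this assay, the group on this carbonyl carbon proved able to shift the number beyond the scatter, which the swap between the two dimethoxyphenyl groups did not show: that earlier change gave only a 1.8-fold higher number from compound 2 to compound 3 (0.24 log units; within the scatter). Pyridin-2-yl in place of 2,6-dimethoxyphenyl gives a 7.6-fold lower number from compound 3 to compound 4 (0.88 log units; beyond the scatter), and pyridin-2-yl in place of 2,4-dimethoxyphenyl gives a 4.3-fold lower number from compound 2 to compound 4 (0.64 log units; beyond the scatter). Both comparisons point the same way, so among the compounds with true numbers, the one carrying pyridin-2-yl has the lowest number and therefore the strongest inhibition.

This change brings in a ring nitrogen and removes both methoxy groups at once, and nothing given here separates those two parts or explains the gain. A plain phenyl or a pyridin-3-yl group on the same carbonyl carbon would help tell them apart.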